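This account rests on a few compounds, and the source may have more. Where it says the series, first, only, none or still open, it means among the compounds named here.

In a functional assay on a cell-free system (Platelet, plasma, Homo sapiens) for inhibition (on this read-out lower numbers stand for stronger inhibition and higher numbers for weaker inhibition), compound 3 (`O=C(NC[C@H](NS(=O)(=O)c1ccccc1)C(=O)O)c1ccc(N2CCC(NC3=NCCCN3)CC2)cc1`) gives 290 nM. That lies within the scatter of compound 2 (`O=C(NC[C@H](NS(=O)(=O)c1ccc(O)cc1)C(=O)O)c1ccc(N2CCC(NC3=NCCCN3)CC2)c(F)c1`) at 230 nM, while compound 1 (`O=C(NC[C@H](NS(=O)(=O)c1cccs1)C(=O)O)c1ccc(N2CCC[C@H](NC3=NCCCN3)C2)cc1`) at 99 nM has a lower number, and that gap lies beyond the scatter. Compound 4 (`O=C(NC[C@H](NS(=O)(=O)c1ccccc1)C(=O)O)c1ccc(N2CCC(NC3=NCCCN3)CC2)c(O)c1`) differs from compound 3 by hydroxy in place of hydrogen on an aromatic carbon, ortho to a large group and meta to a large group (hydroxy in place of hydrogen on an aromatic carbon). Going by the values given here, no measured pair isolates a single change, so the data offer no direct guide to this one. In this assay, no step beyond the scatter is expected. The expected step is a 1.2-fold lower number from compound 3 to compound 4 (0.06 log units; within the scatter). For compound 4 the estimated value is 250 nM, with an expected range of 90 nM to 700 nM.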

Compound 4, half-maximal inhibitory concentration: 170 nM
For compound 4 the middle estimate is 1.5-fold (0.17 log units) above the measured one; the range from low to high includes it.
By their numbers in this assay, from the lowest: compounds 1, 4, 2 and 3 (each within the scatter of the next, the first and the last beyond it).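

Compound 3 and compound 4 form the only pair shown that isolates one change. In this assay, hydroxy in place of hydrogen on this aromatic carbon, ortho to a large group and meta to a large group, gives a 1.7-fold lower number from compound 3 to compound 4 (0.23 log units; within the scatter) and so leaves the read-out unresolved from the scatter, showing that this position accepts a hydroxy. Nothing available explains this step.

On these data alone, whether a methoxy group or an amine at this position would do the same remains open. So does whether hydroxy behaves alike on the core of compound 1.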